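The source may report more compounds than this note shows. Statements on the series, on what has been measured and on what is new or still open speak of the compounds shown alone.

Compound 1 `CC(C)=CCOc1cc(Nc2nccc(C)n2)ccc1Cl` sits at a limit in a functional assay on MT2 cells (Homo sapiens) for cytotoxicity; a higher number here means that more compound is tolerated, a lower number that less compound is tolerated: it gives < 200 nM, a bound of this assay rather than a number. Among the compounds with values here, compound 2 `CC(C)=CCOc1cc(Nc2nccc(N)n2)ccc1Cl` gives 500 nM in this assay, the only numerical value available. The step of an at least 2.5-fold higher number from compound 1 to compound 2 (0.39 log units; beyond the scatter) is itself anchored on that limit (the limit of < 200 nM in this assay, at which 1 of the 2 values shown sits), so its true size is only known as a lower bound.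

Compound 3 `CC(C)=CCOc1cc(Nc2nccc(C(F)(F)F)n2)ccc1Cl` differs from compound 2 by trifluoromethyl in place of amino on an aromatic carbon. Within the data shown here, the single measured step bears on this only by analogy, since it added the amino group that is now removed, and it moved the number upward. Removing the amino group is therefore expected to move the number back down, and the step from compound 2 to compound 3 is estimated at a 2.0-fold lower number from compound 2 to compound 3 (0.30 log units; within the scatter). For compound 3 the expected value in this assay is 250 nM, within a range from 100 nM to 700 nM.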

Compound 3, half-maximal cytotoxic concentration: 2500 nM
The estimate for compound 3 lay 10-fold (1.00 log units) below the measured number; measured number above the stated range.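

In this assay, trifluoromethyl in place of amino gives a 5.0-fold higher number from compound 2 to compound 3 (0.70 log units; beyond the scatter), so amino is not the group at this position that allows the most compound to be tolerated among the three shown. Trifluoromethyl in place of methyl gives an at least 12-fold higher number from compound 1 to compound 3 (1.09 log units; beyond the scatter), and this step is only a lower bound because it rests on a limit of the assay: the limit of < 200 nM in this assay, at which 1 of the 3 values shown sits. The number thus depends strongly on the group at this one position, with each exchange shown there reaching beyond the scatter.

On these data alone, it stays open whether the rise belongs to trifluoromethyl alone or would also appear with a nitrile, a methoxy group or a chlorine at this position. As far as these compounds go, the true size of the step from methyl also remains open.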